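The source may report more compounds than this note shows. Statements on the series, on what has been measured and on what is new or still open speak of the compounds shown alone.

In an in vitro ADME assay on microsomes from liver (Homo sapiens) for pharmacokinetics, read by LC-MS, with a stated time of 10 min, tested at 1 uM (on this read-out higher numbers stand for fast clearance and lower numbers for slow clearance), compound 2 `CN1C[C@H](C(=O)Nc2ccc(F)cc2F)[C@@H](c2ccc(/C=C/C(=O)Nc3ccccc3N)cc2)C1` gives 12 mL/min/kg, and compound 1 `Cc1cc(NC(=O)[C@H]2CN(C)C[C@@H]2c2ccc(/C=C/C(=O)Nc3ccccc3N)cc2)ccc1F` gives 15 mL/min/kg. These two numbers lie within the usual scatter of each other, so the data cannot tell the two compounds apart on this read-out. Within the data shown here, the one measured step that bears on the change at hand is a 1.3-fold lower number from compound 1 to compound 2 (0.10 log units; within the scatter), an exchange of one aryl group for another on the same amide-type nitrogen. Compound 3 `CN1C[C@H](C(=O)Nc2ccccn2)[C@@H](c2ccc(/C=C/C(=O)Nc3ccccc3N)cc2)C1` carries the change (pyridin-2-yl in place of 2,4-difluorophenyl on an amide-type nitrogen). Among the measured compounds shown here, no measured compound bears a pyridin-2-yl on that nitrogen, so nothing in the data points to a direction. Because the exchange a 1.3-fold lower number from compound 1 to compound 2 (0.10 log units; within the scatter) stayed within the scatter, the step expected here, no change at the digits printed from compound 2 to compound 3 (within the scatter), is estimated to be no larger than the scatter either. Compound 3 is therefore expected to give about 12 mL/min/kg in this assay, with a range from 6 mL/min/kg to 24 mL/min/kg.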

Compound 3, clearance: 8 mL/min/kg
The estimate for compound 3 lay 1.5-fold (0.18 log units) above the measured number; the range from low to high includes it.
By their numbers in this assay, from the lowest: compounds 3, 2 and 1 (each within the scatter of the next).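

Swapping the carbon-only aromatic rings on this amide-type nitrogen for pyridin-2-yl, a ring that holds a nitrogen and a hydrogen-bond acceptor, does not move the read-out in this assay beyond the scatter. This holds against both earlier groups: the exchange for 2,4-difluorophenyl (a 1.5-fold lower number from compound 2 to compound 3 (0.18 log units; within the scatter)) and the exchange for 4-fluoro-3-methylphenyl (a 1.9-fold lower number from compound 1 to compound 3 (0.27 log units; within the scatter)). The earlier compounds compared only fluorinated carbon rings, so the position now also accepts a ring with a hetero atom and no fluorine without a clear change in clearance, and no measurement here explains these numbers.

Still open, from the compounds shown here alone, is how clearance responds on this nitrogen to a group that is not an aromatic ring, such as a simple alkyl chain. A chain ending in an amine or a carboxylic acid is equally untested among the compounds shown.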